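A few compounds are considered here, and "the series" means these few. Any claim that something is new, unique, unknown or untested is made for them only; others in the source may bear on it.

Compound 1 `O=C(Nc1cccc(-n2cc(-c3ccncc3)c(-c3cc(O)cc(Cl)c3)n2)c1)Nc1ccc(Cl)c(C(F)(F)F)c1` gives 99% in a functional assay on SK-MEL-2 cells (Homo sapiens) for inhibition, read by sulforhodamine B assay, with a stated time of 48 h, tested at 0.01 uM; a higher number here means a weaker effect of the compound at the concentration tested, a lower number a stronger effect.
Compound 2 `COc1cc(Cl)cc(-c2nn(-c3cccc(NC(=O)Nc4ccc(Cl)c(C(F)(F)F)c4)c3)cc2-c2ccncc2)c1` gives 102% in this assay.

In this assay compound 2 stands highest of the two numbers, with compound 1 nearest, and the step of a number 3 percentage points higher from compound 1 to compound 2 (within the scatter) lies within the scatter, so the two compounds cannot be told apart. Compound 3 `COc1cc(Cl)cc(-c2nn(-c3cccc(NC(=O)c4cccc(C(F)(F)F)c4)c3)cc2-c2ccncc2)c1` has not been measured in this assay. It differs from compound 2 in one place: 3-(trifluoromethyl)phenyl in place of (4-chloro-3-(trifluoromethyl)phenyl)amino on a carbonyl carbon. Within the data shown here, the only measured step concerns methyl in place of hydrogen on an oxygen on an aromatic ring, a change in another part of the molecule, and it was a number 3 percentage points higher from compound 1 to compound 2 (within the scatter); no measured step involves the group on the carbonyl carbon. Among the measured compounds shown here, both numbers so far sit near full activity, so for compound 3 the expected step is a number 2 percentage points lower from compound 2 to compound 3 (within the scatter), none beyond the scatter. Compound 3 is therefore estimated at 100%, with a range from 85% to 110%.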

Compound 3, a percentage reported as activity, at one concentration (the size of the read-out at that concentration, not a potency): 52%
The estimate for compound 3 lay 48 percentage points above the measured number; the measured number lies below the stated range.
By their numbers in this assay, from the lowest: compound 3; then compounds 1 and 2 (each within the scatter of the next).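

In this assay, among these compounds, the group on the carbonyl carbon is the first place where the read-out clearly moves: 3-(trifluoromethyl)phenyl in place of (4-chloro-3-(trifluoromethyl)phenyl)amino gives a number 50 percentage points lower from compound 2 to compound 3 (beyond the scatter), a stronger effect at the concentration tested. The earlier pair, which differs only by a methyl on an oxygen, showed no difference that could be separated from the scatter, so it gave no hint that this position would respond. Nothing available explains why this change has such an effect.

The step removes the amino nitrogen and the chlorine together, so the compounds shown cannot tell which loss matters, or whether both do. On these data alone, it remains open how (3-(trifluoromethyl)phenyl)amino or 4-chloro-3-(trifluoromethyl)phenyl on the carbonyl carbon would read, each of which would separate the two.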